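Benzyl replaces hydroxyethyl on the urea end of a biaryl series

The compounds below may be only part of what the source reports. "The series", "measured", "known", "first", "only" and "open" are said of these compounds alone.

Measured compounds:
compound 1 `CNC(=O)Nc1ccccc1-c1ccc(CN2C(=O)[C@H](NC(=O)CC(C)(C)N)CCc3ccccc32)cc1` gives 50 nM
compound 2 `CC(C)(N)C(=O)N[C@@H]1CCc2ccccc2N(Cc2ccc(-c3ccccc3CNC(N)=O)cc2)C1=O` gives 21 nM
compound 3 `CC(C)(N)C(=O)N[C@@H]1CCc2ccccc2N(Cc2ccc(-c3ccccc3CNC(=O)NCCO)cc2)C1=O` gives 2 nM

All three share one core and were tested in a functional assay (Pituitary gland cell) with Rattus norvegicus as the target; a higher number here means that more compound is needed for the effect, a lower number that less compound is needed. Compound 3 stands lowest of the three; its nearest neighbour is compound 2, and compound 1 lies furthest away. Among the measured compounds shown here, the only single-point step among them is an 11-fold lower number from compound 2 to compound 3 (1.02 log units; beyond the scatter), which came with 2-hydroxyethyl in place of hydrogen on an amide-type nitrogen.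

Compound 4 `CC(C)(N)C(=O)N[C@@H]1CCc2ccccc2N(Cc2ccc(-c3ccccc3CNC(=O)NCc3ccccc3)cc2)C1=O` has not yet been measured. It differs from compound 3 by phenyl in place of hydroxymethyl on a saturated chain carbon bound to an amide-type nitrogen, that is, 2-hydroxyethyl to benzyl. For the measured compounds named here, no measured step bears directly on this exchange: the one step known, from compound 2 to compound 3, shows that filling this position matters, but says nothing about a phenyl in place of the hydroxymethyl. The outcome in this assay is therefore uncertain, and a modest loss is expected rather than a gain.

Compound 4 is estimated at 5 nM, with a range from 1.5 nM to 20 nM. This estimate means a step of a 2.5-fold higher number from compound 3 to compound 4 (0.40 log units; beyond the scatter).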

Compound 4, concentration for half-maximal effect: 390 nM
The estimate for compound 4 lay 78-fold (1.89 log units) below the measured number, outside the stated range (above it).
By their numbers in this assay, from the lowest: compound 3; then compound 2; then compound 1; then compound 4.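

In this assay, replacing hydroxymethyl with phenyl on a saturated chain carbon bound to an amide-type nitrogen, that is, 2-hydroxyethyl to benzyl, brought a 200-fold higher number from compound 3 to compound 4 (2.29 log units; beyond the scatter) and took the series from its lowest number to its highest. Relative to hydrogen on the same amide-type nitrogen, benzyl gave a 19-fold higher number from compound 2 to compound 4 (1.27 log units; beyond the scatter) while 2-hydroxyethyl gave an 11-fold lower number from compound 2 to compound 3 (1.02 log units; beyond the scatter), so the group here can move the number in either direction, and filling the position does not by itself lower it. Nothing available explains the gap between these two groups.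

The compounds shown leave open whether the rise goes with the arrival of the phenyl ring or with the loss of the hydroxyl. A plain ethyl chain on this nitrogen would help separate the two, while a 2-aminoethyl group or a longer 3-hydroxypropyl chain would show how closely the low number of compound 3 depends on 2-hydroxyethyl itself.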